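From methoxy to fluoro: working notes on compound 3

The compounds below may be only part of what the source reports. "The series", "measured", "known", "first", "only" and "open" are said of these compounds alone.

Measured so far in an ADME assay for permeability, using PAMPA, with a stated time of 4 h, at pH 7.4, tested at 100 uM; a higher number here means that the compound crosses the layer faster, a lower number that the compound crosses the layer more slowly:
- compound 1 `Cc1nc2cc(-c3cccc(-c4ccccc4)c3)nn2c(-c2cc(F)c3c(c2C)CCCO3)c1[C@H](OC(C)(C)C)C(=O)O` gives 733 nm/s
- compound 2 `COc1ccccc1-c1cccc(-c2cc3nc(C)c([C@H](OC(C)(C)C)C(=O)O)c(-c4cc(F)c5c(c4C)CCCO5)n3n2)c1` gives 765 nm/s

Compound 2 stands within the scatter of compound 1, so neither ranks ahead. The next compound is compound 3 `Cc1nc2cc(-c3cccc(-c4ccccc4F)c3)nn2c(-c2cc(F)c3c(c2C)CCCO3)c1[C@H](OC(C)(C)C)C(=O)O`, not yet measured. The change from compound 2 is fluoro in place of methoxy on an aromatic carbon. Among the measured compounds shown here, only one measured step bears on this: adding the methoxy gave a 1.0-fold higher number from compound 1 to compound 2 (0.02 log units; within the scatter). No step beyond the scatter is therefore expected in this assay. The expected change is a 1.0-fold lower number from compound 2 to compound 3 (0.01 log units; within the scatter) as estimated here. For compound 3 the estimate is 750 nm/s, with an expected range of 450 nm/s to 1200 nm/s.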

Compound 3, apparent permeability: 608 nm/s
Beside the measured number, compound 3's estimate is 1.2-fold (0.09 log units) above it; the measured number falls inside the stated range.
By their numbers in this assay, from the lowest: compounds 3, 1 and 2 (each within the scatter of the next).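

In this assay, fluoro in place of methoxy gives a 1.3-fold lower number from compound 2 to compound 3 (0.10 log units; within the scatter) and fluoro in place of hydrogen gives a 1.2-fold lower number from compound 1 to compound 3 (0.08 log units; within the scatter) on the same aromatic carbon. This position, ortho to a large group, has now carried hydrogen, methoxy and fluoro, and all the steps among these three groups lie within the scatter. No measurement at hand offers an explanation for these small differences.

As far as these compounds go, whether this tolerance extends to groups of another kind remains open. An amine or a carboxylic acid on this aromatic carbon would test that.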